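The compounds below may be only part of what the source reports. "The series", "measured", "known", "first", "only" and "open" are said of these compounds alone.

Compound 1 `COc1ccc(OS(=O)(=O)c2ccc(N3CCN(C)C3=O)cc2)cc1OC` and compound 2 `COc1ccc(OS(=O)(=O)c2ccc(N3CCN(C)C3=O)cc2)cc1` share one core and differ in a single methoxy group. In a functional assay on HT-29 cells (Homo sapiens) for antiproliferative activity, read by sulforhodamine B assay, with a stated time of 48 h (on this read-out lower numbers stand for stronger inhibition and higher numbers for weaker inhibition), compound 1 gives 12000 nM. For compound 2 this assay reports only a limit, > 100000 nM. The change methoxy in place of hydrogen on an aromatic carbon thus makes an at least 8.3-fold lower number from compound 2 to compound 1 (0.92 log units; beyond the scatter), a step bounded by the limit of > 100000 nM in this assay, at which 2 of the 3 values shown sit. Compound 3 `CCCCN1CCN(c2ccc(S(=O)(=O)Oc3ccccc3)cc2)C1=O` has another core; how it differs from compound 2 is not broken down here. For compound 3 this assay again reports only a limit, > 100000 nM. Compound 4 `CCCCN1CCN(c2ccc(S(=O)(=O)Oc3ccccc3OC)cc2)C1=O` carries methoxy in place of hydrogen on an aromatic carbon, the same kind of change, though the place differs: ortho to a large group rather than ortho to a methoxy group and meta to a large group. The expected step of an at least 1.6-fold lower number from compound 3 to compound 4 (0.22 log units; that floor lies within the scatter) is held modest due to the limit of > 100000 nM in this assay, at which 2 of the 3 values shown sit, and the different place. Compound 4 is expected to give about 60000 nM, between 15000 nM and 200000 nM.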

Compound 4, half-maximal inhibitory concentration: > 100000 nM
Compound 4: no number, only a limit (the forecaster's own chance of this, stated with the estimate: 50%); middle value at least 1.6-fold (0.22 log units) from the limit.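

No new step can be read from compound 3 to compound 4, because each gives only a limit rather than a number: the limit of > 100000 nM in this assay, at which 3 of the 4 values shown sit. The compounds shown leave open whether 2-methoxyphenyl in place of phenyl changes activity on the core of compound 3 at all.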